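A few compounds are considered here, and "the series" means these few. Any claim that something is new, unique, unknown or untested is made for them only; others in the source may bear on it.

Series notes, cytotoxicity in cultured cells.

The series is read in a functional assay on HeLa cells (Homo sapiens) for cytotoxicity, read by WST assay, with a stated time of 48 h; a lower number here means a stronger inhibitor, a higher number a weaker inhibitor. Compound 1 `Cc1ccc(/C=C/C[C@H]2C[C@@H]([C@@H](O)c3ccccc3)CO[C@@H]2c2ccccc2)cc1C` gives the lowest of the two numbers to hand: in this assay compound 1 gives 10000 nM. The nearest measured neighbour is compound 3 `COc1ccc(/C=C/C[C@H]2C[C@H]([C@H](O)c3ccc(OC)c(OC)c3)CO[C@@H]2c2ccc(OC)c(OC)c2)cc1OC`, which in this assay gives 34600 nM, a gap from compound 1 that lies beyond the scatter of repeat measurements. Compound 2 `COc1ccc(/C=C/C[C@@H]2C[C@@H]([C@@H](OC(C)=O)c3ccc(OC)c(OC)c3)CO[C@H]2c2ccc(OC)c(OC)c2)cc1OC` returns only a limit in this assay, > 100000 nM; it is a limit of the assay and not a number, the one described by the limit of > 100000 nM in this assay, at which 1 of the 3 values shown sits. Among the measured compounds shown here, no two of the measured compounds differ in a single place, so no measured step is available to calibrate the change below.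

The unmeasured compound 4 `O[C@@H](c1ccccc1)[C@H]1CO[C@H](c2ccccc2)[C@@H](C/C=C/C2CCCC2)C1` is compared with compound 1. The difference is cyclopentyl in place of 3,4-dimethylphenyl on a double-bonded chain carbon bound to a double-bonded chain carbon. Nothing among the measured compounds speaks to this particular exchange, so the expectation rests on the general picture that compound 1 is the lowest of the numbers shown and that the other two sit weaker or at the limit. A modest loss is expected, of the size a 2.0-fold higher number from compound 1 to compound 4 (0.30 log units; within the scatter), though a change within the scatter would not be surprising. Compound 4 is therefore estimated at 20000 nM in this assay, with a plausible range from 6000 nM to 70000 nM.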

Compound 4, half-maximal inhibitory concentration: 9330 nM
Compound 4: the middle estimate sits 2.1-fold (0.33 log units) above what was measured, within the range that was stated.
By their numbers in this assay, from the lowest: compounds 4 and 1 (each within the scatter of the next); then compound 3. At a limit, above all of these: compound 2.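

In this assay, cyclopentyl in place of 3,4-dimethylphenyl on a double-bonded chain carbon bound to a double-bonded chain carbon comes out as a 1.1-fold lower number from compound 1 to compound 4 (0.03 log units; within the scatter) and so compound 1 and compound 4 read alike. Among the compounds shown here, this is the only measured step so far, and it shows that, on the core of compound 1, a six-membered aromatic ring of carbon with 8 heavy atoms is not needed at this place for a reading of this size, since a five-membered non-aromatic ring of carbon with 5 heavy atoms serves equally well. The measurements at hand say nothing about why the two groups read alike.

On these data alone, one exchange at one place cannot show how far this tolerance extends, and whether an amine, a carboxylic acid or a longer chain ending in a cyclohexyl ring at the same place would also read alike remains open. Also open, as far as these compounds go, is whether the exchange would read the same way on a core carrying the methoxy groups of compound 3, or whether any change at this place can separate itself from the scatter at all.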